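Swapping Bromo for Cyano on One Amide Nitrogen

This account rests on a few compounds, and the source may have more. Where it says the series, first, only, none or still open, it means among the compounds named here.

Of the compounds shown here, three sharing one core have been tested in a functional assay on A549 cells (Homo sapiens) for inhibition, read by CCK-8 assay, with a stated time of 72 h, tested at 1 uM; on this read-out lower numbers stand for less inhibition of growth and higher numbers for more inhibition of growth at the one concentration tested. Here compound 1 `Cc1ccc(NC(=O)C2(C(=O)Nc3ccc(Nc4ncc5cc(C(=O)N(C)C)n(C6CCCC6)c5n4)cc3)CC2)cc1` gives 40.2%, compound 2 `CN(C)C(=O)c1cc2cnc(Nc3ccc(NC(=O)C4(C(=O)Nc5cccc(C(F)(F)F)c5)CC4)cc3)nc2n1C1CCCC1` gives 15.7%, and compound 3 `CN(C)C(=O)c1cc2cnc(Nc3ccc(NC(=O)C4(C(=O)Nc5cccc(Br)c5)CC4)cc3)nc2n1C1CCCC1` gives 20.2%. Compound 3 thus sits level with compound 2, within the usual scatter, and clearly under compound 1.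

The next compound, compound 4 `CN(C)C(=O)c1cc2cnc(Nc3ccc(NC(=O)C4(C(=O)Nc5ccc(C#N)cc5)CC4)cc3)nc2n1C1CCCC1`, carries 4-cyanophenyl in place of 3-bromophenyl on an amide-type nitrogen. Three measured steps changed this same group. Two were modest: a number 24.5 percentage points lower from compound 1 to compound 2 (beyond the scatter) and a number 20 percentage points lower from compound 1 to compound 3 (beyond the scatter). The third, a number 4.5 percentage points higher from compound 2 to compound 3 (within the scatter), stays within the scatter, so exchanging those two groups told little.

The name of the new group carries the same number as the 4-methylphenyl of compound 1, the best of the three at 40.2%. That is thin evidence, since it rests on one compound and a nitrile is not a methyl. A partial climb towards compound 1 is therefore expected, not a full recovery. The expected change is small and upward, a number 9.8 percentage points higher from compound 3 to compound 4 (within the scatter). The estimated growth inhibition for compound 4 is 30%, with an expected range from 14% to 47%.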

Compound 4, percent growth inhibition at one concentration: 86.1%
Estimate against measurement, compound 4: 56.1 percentage points below; measured number outside the range, above it.
By their numbers in this assay, from the lowest: compounds 2 and 3 (each within the scatter of the next); then compound 1; then compound 4.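

The group on the amide-type nitrogen can shift the result in this assay much further than the first three compounds revealed: replacing 3-bromophenyl with 4-cyanophenyl gives a number 65.9 percentage points higher from compound 3 to compound 4 (beyond the scatter) and replacing 3-(trifluoromethyl)phenyl with it gives a number 70.4 percentage points higher from compound 2 to compound 4 (beyond the scatter) on the same shared core. The tightest comparison exchanges only methyl for cyano on an aromatic carbon and still gives a number 45.9 percentage points higher from compound 1 to compound 4 (beyond the scatter) in this series, so two groups with the same number in their names can lie far apart on this read-out. Nothing available here explains the size of these steps.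

With a single nitrile-bearing compound, the rise cannot yet be assigned to the nitrile itself or to where it sits on the ring, and a 3-cyanophenyl group on the same nitrogen would help separate those two readings. As far as these compounds go, it also remains open whether the high value is peculiar to the nitrile or is shared by other groups at that ring position, such as a carboxylic acid, an amine or an acetyl group.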